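The compounds below may be only part of what the source reports. "The series", "measured", "known", "first", "only" and "open" are said of these compounds alone.

Compound 1 `O=C(/C=C/c1cccnc1)NCCCc1ccc(S(=O)(=O)Nc2ccccc2)cc1` in a functional assay on HeLa cells (Homo sapiens) for inhibition, read by CCK-8 assay, with a stated time of 72 h (a lower number here means a stronger inhibitor, a higher number a weaker inhibitor), gives > 10000 nM as a limit
Compound 2 `O=C(/C=C/c1cccnc1)NCCCCCCc1cccc(S(=O)(=O)Nc2ccccc2)c1` in this assay gives 30.4 nM
Compound 3 `O=C(/C=C/c1cccnc1)NCCCCCCCc1cccc(S(=O)(=O)Nc2ccccc2)c1` in this assay gives 598 nM

The entry for compound 1 is a limit and not a number. Of the two actual numbers, compound 2 holds the lower, and the gap up to compound 3 lies beyond the usual scatter.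

Compound 4 `Cc1cccc(NS(=O)(=O)c2cccc(CCCCCCNC(=O)/C=C/c3cccnc3)c2)c1` differs from compound 2 only at the anilino end, which becomes (3-methylphenyl)amino. The difference is methyl in place of hydrogen on an aromatic carbon. Among the measured compounds shown here, none of the measured compounds carries such a change, so the expectation starts from compound 2 at 30.4 nM and is for no step beyond the scatter in this assay or perhaps a small rise in the number. The estimated move is a 1.3-fold higher number from compound 2 to compound 4 (0.12 log units; within the scatter) by this reckoning. For compound 4 the expected half-maximal inhibitory concentration is 40 nM with an estimated range of 12 nM to 150 nM on this view.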

Compound 4, half-maximal inhibitory concentration: 65.8 nM
The estimate for compound 4 lay 1.6-fold (0.22 log units) below the measured number; measured number inside the range.
By their numbers in this assay, from the lowest: compound 2; then compound 4; then compound 3. At a limit, above all of these: compound 1.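

In this assay, among the compounds shown here, the earlier compounds offered no step at a single place, so they said nothing about the anilino end; this pair gives the first such reading. Going from phenyl to 3-methylphenyl, a change of one carbon on the aromatic ring, gives a 2.2-fold higher number from compound 2 to compound 4 (0.34 log units; beyond the scatter), so this end of the molecule responds to even a single methyl, though only modestly. Nothing at hand gives a cause for this step.

The compounds shown leave open how a fluorine, a methoxy or an amine on this same carbon would compare with the methyl, and whether a larger group such as ethyl would widen the step. They also leave open whether a methyl on another carbon of this ring would give a step of similar size.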